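The source may hold more compounds than are shown below. What is called first, only, known or untested is meant among the compounds shown, and "the series" means these compounds.

Measured so far in a functional assay on HCT-116 cells (Homo sapiens) for cytotoxicity, read by resazurin assay, with a stated time of 48 h; on this read-out higher numbers stand for an effect only at larger amounts of compound and lower numbers for an effect already at smaller amounts:
- compound 1 `COc1ccc(S(=O)(=O)Nc2ccc3oc(-c4ccc(NC(=O)c5ccc(Cl)s5)cc4)nc3c2)cc1` gives 5400 nM
- compound 2 `COc1ccc(S(=O)(=O)Nc2ccc3oc(-c4ccc(NS(=O)(=O)c5cc(Br)ccc5OC)cc4)nc3c2)cc1` gives 12000 nM

Compound 2 at 12000 nM has the higher number of the two, so it needs more compound for the same effect. Compound 3 `COc1ccc(S(=O)(=O)Nc2ccc3oc(-c4ccc(NS(=O)(=O)c5cc(F)ccc5OC)cc4)nc3c2)cc1` carries fluoro in place of bromo on an aromatic carbon and is otherwise the same. Among the compounds with values here, the one measured step of a 2.2-fold higher number from compound 1 to compound 2 (0.35 log units; beyond the scatter) is modest and exchanged a whole group on a nitrogen, so it is only a loose guide. Within the data shown here, no measured pair tests this swap, so no step beyond the scatter is expected in this assay in either direction. The expected step is no change at the digits printed from compound 2 to compound 3 (within the scatter) and nothing firmer. Compound 3 is estimated at 12000 nM with a range from 5000 nM to 30000 nM on this read-out.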

Compound 3, half-maximal effective concentration: 15000 nM
The estimate for compound 3 lay 1.3-fold (0.10 log units) below the measured number, and the stated range covers the measured number.
By their numbers in this assay, from the lowest: compound 1; then compounds 2 and 3 (each within the scatter of the next).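

In this assay the exchange of bromo for fluoro, on the carbon para to the methoxy group, gives a 1.3-fold higher number from compound 2 to compound 3 (0.10 log units; within the scatter) and so leaves the two compounds indistinguishable at this position. The gap to the chlorothiophene amide persists with either halogen, with a 2.8-fold higher number from compound 1 to compound 3 (0.44 log units; beyond the scatter) as the step for the fluoro compound. No supporting measurement bears on why this is so.

From the compounds shown here alone, whether this position tolerates anything beyond these two halogens remains open. An amine or a nitrile in the same place could behave quite differently.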